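Thiophene replaces formylphenyl at the aryl position

The source may report more compounds than this note shows. Statements on the series, on what has been measured and on what is new or still open speak of the compounds shown alone.

Compound 2 `O=Cc1ccc(-c2cn3ccnc3c(-c3ccc4ncn(C5CCCCC5)c4c3)n2)cc1` gives 0.75% in a functional assay on TK-10 cells (Homo sapiens) for inhibition, read by sulforhodamine B assay, with a stated time of 48 h, tested at 10 uM (a lower number here means less inhibition, a higher number more inhibition at the concentration tested (going by the name of the read-out)), the lowest of the two numbers measured, while compound 1 `c1ccc(-c2cn3ccnc3c(-c3ccc4ncn(C5CCCCC5)c4c3)n2)cc1` gives 2.26%; the two lie within the scatter of each other, as the step of a number 1.5 percentage points lower from compound 1 to compound 2 (within the scatter) shows. Compound 3 `c1cn2cc(-c3ccsc3)nc(-c3ccc4ncn(C5CCCCC5)c4c3)c2n1` has not yet been measured. The change from compound 2 to compound 3 is thiophen-3-yl in place of 4-formylphenyl on an aromatic carbon. Going by the values given here, the only measured step, from hydrogen to formyl, touches a substituent on the phenyl ring that itself leaves here, so it does not bear on an exchange of the whole aryl group, and no other step is available. Both measured compounds sit close to no inhibition, and nothing suggests that the thiophene will move far from them. Compound 3 is therefore expected to show a step of a number 1.3 percentage points higher from compound 2 to compound 3 (within the scatter), with an estimated value of 2%, lying between -8% and 14%.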

Compound 3, a percentage reported as inhibition, at one concentration (the size of the read-out at that concentration, not a potency): 3.37%
For compound 3 the middle estimate is 1.4 percentage points below the measured one, and the stated range covers the measured number.
By their numbers in this assay, from the lowest: compounds 2, 1 and 3 (each within the scatter of the next).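

In this assay, going by these compounds alone, this is the first exchange of the whole aryl group at this position, and it stays within the scatter: the reading is a number 2.6 percentage points higher from compound 2 to compound 3 (within the scatter) and also a number 1.1 percentage points higher from compound 1 to compound 3 (within the scatter) at the same position. Thiophen-3-yl, with its five-membered aromatic ring, therefore cannot be told apart here from either 4-formylphenyl or phenyl, although it carries fewer heavy atoms than 4-formylphenyl. All three compounds remain close to no inhibition at the concentration tested, and nothing available accounts for this reading.

From the compounds shown here alone, it remains open whether any group at this position, such as an amine, a carboxylic acid or a longer alkyl chain, would give a reading beyond the scatter. Going by these compounds, it is also open whether these three compounds would separate at another concentration.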